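Substituent change on the shared core: compound 3 to compound 4

A few compounds are considered here, and "the series" means these few. Any claim that something is new, unique, unknown or untested is made for them only; others in the source may bear on it.

In an ADME assay on PC-3 cells (Homo sapiens) for cytotoxicity, read by WST assay, tested at 100 uM (a lower number here means less inhibition, a higher number more inhibition at the concentration tested (going by the name of the read-out)), compound 1 `CSc1cccc(NC(=O)C2CCCN(C(=O)c3cc(C(F)(F)F)cc(C(F)(F)F)c3)C2)c1` gives 0%, compound 2 `O=C(Nc1cccc(CN2CCCC2)c1)C1CCCN(C(=O)c2cc(C(F)(F)F)cc(C(F)(F)F)c2)C1` gives 51%, and compound 3 `O=C(Nc1cccc(OCCc2ccccn2)c1)C1CCCN(C(=O)c2cc(C(F)(F)F)cc(C(F)(F)F)c2)C1` gives 5%. Compound 3 stands second highest of the three numbers; its nearest neighbour is compound 1, with a number 5 percentage points higher from compound 1 to compound 3 (within the scatter), and its furthest is compound 2, with a number 46 percentage points lower from compound 2 to compound 3 (beyond the scatter). Compound 4 `COC(=O)c1cc(-c2cccc(NC(=O)C3CCCN(C(=O)c4cc(C(F)(F)F)cc(C(F)(F)F)c4)C3)c2)co1` carries 5-(methoxycarbonyl)furan-3-yl in place of 2-(pyridin-2-yl)ethoxy on an aromatic carbon. Both measured steps touch this same position: the pyrrolidinylmethyl group gave a large step, the pyridinylethoxy group none beyond the scatter. Within the data shown here, no measured step involves the entering group, so the expectation rests on the low values of compound 1 and compound 3. For compound 4 the step of a number 3 percentage points higher from compound 3 to compound 4 (within the scatter) is expected to stay within the scatter. Compound 4 is therefore estimated at 8%, range 0% to 30%.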

Compound 4, a percentage reported as inhibition, at one concentration (the size of the read-out at that concentration, not a potency): 0%
Compound 4: middle estimate off by 8 percentage points, on the high side; the measured number falls inside the stated range.
By their numbers in this assay, from the lowest: compounds 1, 4 and 3 (each within the scatter of the next); then compound 2.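

In this assay a third group at this position stays with the low readings, with a number 5 percentage points lower from compound 3 to compound 4 (within the scatter) and no change at the digits printed from compound 1 to compound 4 (within the scatter) on entry of 5-(methoxycarbonyl)furan-3-yl. Against the (pyrrolidin-1-yl)methyl group there is a number 51 percentage points lower from compound 2 to compound 4 (beyond the scatter) here, so compound 2 remains the only one of the four set apart from the others. No measured evidence bears on this split.

Open, on these data alone, is whether another amine at this position, such as piperidin-1-ylmethyl or dimethylaminomethyl, reads like compound 2. Also open, as far as these compounds go, is how a carboxylic acid in place of the methyl ester on the furan reads.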